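Biphenyl in place of tolyl: a permeability forecast

The compounds below may be only part of what the source reports. "The series", "measured", "known", "first", "only" and "open" are said of these compounds alone.

Compound 1 `Cc1nc2cc(-c3ccccc3)nn2c(-c2cc(F)c3c(c2C)CCCO3)c1C(OC(C)(C)C)C(=O)O`: 218 nm/s
Compound 2 `Cc1nc2cc(-c3ccccc3)nn2c(N2CCC(C)(C)CC2)c1C(OC(C)(C)C)C(=O)O`: 703 nm/s
Compound 3 `Cc1ccc(-c2cc3nc(C)c(C(OC(C)(C)C)C(=O)O)c(-c4cc(F)c5c(c4C)CCCO5)n3n2)cc1`: 492 nm/s

In an ADME assay for permeability, using PAMPA, with a stated time of 4 h, at pH 7.4, tested at 100 uM (a higher number here means that the compound crosses the layer faster, a lower number that the compound crosses the layer more slowly), compound 3 stands second highest of the three numbers shown, close to compound 2 and apart from compound 1. Compound 4 `Cc1nc2cc(-c3cccc(-c4ccccc4)c3)nn2c(-c2cc(F)c3c(c2C)CCCO3)c1C(OC(C)(C)C)C(=O)O` differs from it by one change: 3-phenylphenyl in place of 4-methylphenyl on an aromatic carbon. The step that bears most directly on this is a 2.3-fold higher number from compound 1 to compound 3 (0.35 log units; beyond the scatter), where a group entered at the same ring carbon; the other step, a 3.2-fold higher number from compound 1 to compound 2 (0.51 log units; beyond the scatter), concerns a different position. Neither step shows what a second aromatic ring at this position does, so the expectation rests on the direction of a 2.3-fold higher number from compound 1 to compound 3 (0.35 log units; beyond the scatter) alone. For compound 4 an estimate of 550 nm/s is given, within 250 nm/s to 1100 nm/s, meaning an expected step of a 1.1-fold higher number from compound 3 to compound 4 (0.05 log units; within the scatter).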

Compound 4, apparent permeability: 652 nm/s
The estimate for compound 4 lay 1.2-fold (0.07 log units) below the measured number; the range from low to high includes it.
By their numbers in this assay, from the lowest: compound 1; then compounds 3, 4 and 2 (each within the scatter of the next).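

In this assay, 3-phenylphenyl in place of 4-methylphenyl on this aromatic carbon gives a 1.3-fold higher number from compound 3 to compound 4 (0.12 log units; within the scatter) here, so this position accepts the second aromatic ring without a step beyond the scatter. Read from the hydrogen of the parent ring, the change gives a 3.0-fold higher number from compound 1 to compound 4 (0.48 log units; beyond the scatter) and, like the methyl, is a step beyond the scatter. No measurement is at hand that explains either step.

The compounds shown leave open what an amine or a carboxylic acid on the second phenyl would do. As far as these compounds go, a longer chain in place of that phenyl also remains untested among them.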